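Swapping halogen and methyl on the aryl group of compound 1

A few compounds are considered here, and "the series" means these few. Any claim that something is new, unique, unknown or untested is made for them only; others in the source may bear on it.

Compound 1 `CCCCN(CC)c1cc(C)nc2c1NC(=O)CN2c1ccc(C)cc1Cl` is a fused two-ring core carrying a 2-chloro-4-methylphenyl group on a ring nitrogen. In an assay on HEK-293T cells for displacement of a labelled ligand from corticotropin-releasing factor receptor 1 (Homo sapiens), read by scintillation counting, with a stated time of 2 h (on this read-out lower numbers stand for stronger inhibition and higher numbers for weaker inhibition), compound 1 gives 4.4 nM, the highest number among the three measured compounds. Compound 2 `CCCCN(CC)c1cc(C)nc2c1NC(=O)CN2c1ccc(Br)cc1Br` carries a 2,4-dibromophenyl group instead and gives 1.3 nM; compound 3 `CCCCN(CC)c1cc(C)nc2c1NC(=O)CN2c1ccc(Cl)cc1Br` carries a 2-bromo-4-chlorophenyl group and gives 2.5 nM.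

The new compound 4 `CCCCN(CC)c1cc(C)nc2c1NC(=O)CN2c1ccc(Br)cc1C` differs from compound 1 as follows: 4-bromo-2-methylphenyl in place of 2-chloro-4-methylphenyl on a nitrogen on an aromatic ring in a ring

Two measured steps inform this change. Replacing the 2-chloro-4-methylphenyl group with 2,4-dibromophenyl gave a 3.4-fold lower number from compound 1 to compound 2 (0.53 log units; beyond the scatter), while replacing it with 2-bromo-4-chlorophenyl gave a 1.8-fold lower number from compound 1 to compound 3 (0.25 log units; within the scatter). Both moves put a halogen where the methyl stood and lowered the number, one clearly and one only slightly. Compound 4 keeps a methyl on the ring and adds bromine, so a shift in the same direction seems plausible, though it may well stay inside the scatter.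

Compound 4 is therefore expected to give about 2.5 nM, with a likely range from 1 nM to 6.5 nM. That estimate corresponds to an expected 1.8-fold lower number from compound 1 to compound 4 (0.25 log units; within the scatter).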

Compound 4, inhibition constant: 4.4 nM
The estimate for compound 4 lay 1.8-fold (0.25 log units) below the measured number; measured number inside the range.
By their numbers in this assay, from the lowest: compounds 2, 3, 1 and 4 (each within the scatter of the next, the first and the last beyond it).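

The step to 4-bromo-2-methylphenyl shows no change at the digits printed from compound 1 to compound 4 (within the scatter) in this assay and so gives this position a case where chlorine and methyl are exchanged for bromine and methyl with no visible effect on the number. Compared with 2-bromo-4-chlorophenyl, the same group gives a 1.8-fold higher number from compound 3 to compound 4 (0.25 log units; within the scatter) and stays within the usual spread of repeat measurements, whereas compared with 2,4-dibromophenyl it gives a 3.4-fold higher number from compound 2 to compound 4 (0.53 log units; beyond the scatter) and is a real, if modest, loss; a single bromine on this aryl group is therefore not enough to match the low number of the 2,4-dibromophenyl compound. Nothing measured here explains why these aryl groups differ.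

Going by these compounds, all four aryl groups carry only methyl, chloro or bromo, so it remains open how the number would respond to a methoxy or trifluoromethyl group in place of the methyl of 4-bromo-2-methylphenyl. A 2,4-dimethylphenyl group would show whether a ring with no halogen at all still holds a number in this range.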